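A few compounds are considered here, and "the series" means these few. Any claim that something is new, unique, unknown or untested is made for them only; others in the source may bear on it.

Measured compounds:
compound 1, `C/C(=N/NC(=O)Nc1nc(-c2ccc(F)cc2)cc(-c2ccc([N+](=O)[O-])cc2)n1)c1ccc(C)cc1`, 300 mg/kg
compound 2, `COc1ccc(/C(C)=N\NC(=O)Nc2nc(-c3ccc(F)cc3)cc(-c3ccc([N+](=O)[O-])cc3)n2)cc1`, 100 mg/kg
compound 3, `C/C(=N/NC(=O)Nc1nc(-c2ccc(C)cc2)cc(-c2ccc(F)cc2)n1)c1ccc(Cl)cc1`, 100 mg/kg

In a functional assay on the whole organism (strain Albino) with Mus musculus as the target, with a stated time of 0.5 h (on this read-out lower numbers stand for an effect already at smaller amounts and higher numbers for an effect only at larger amounts of compound), compound 1 gives 300 mg/kg, the highest of the three numbers. The single-place change to compound 2 reads a 3.0-fold lower number from compound 1 to compound 2 (0.48 log units; beyond the scatter). Going by the values given here, compound 3 gives 100 mg/kg, but it differs from compound 1 in more than one place, so no single step is drawn from that pair.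

Compound 4 is `COc1ccc(-c2cc(-c3ccc(F)cc3)nc(NC(=O)N/N=C(/C)c3ccc(C)cc3)n2)cc1`. Its difference from compound 1 is methoxy in place of nitro on an aromatic carbon. Among the compounds with values here, no measured pair shows this exchange. Within the data shown here, the only single-place step in hand, a 3.0-fold lower number from compound 1 to compound 2 (0.48 log units; beyond the scatter), introduces a methoxy group at a different site and moved the number modestly downward; it bears on the present change only in that the same group enters, and the group that leaves is not the same. A modest lowering of the number in this assay is therefore taken as the more likely outcome, with a step within the scatter a close second, and a rise not excluded.

For compound 4 the expected value in this assay is 150 mg/kg, within a range of 60 mg/kg to 400 mg/kg, which amounts to an estimated step of a 2.0-fold lower number from compound 1 to compound 4 (0.30 log units; within the scatter).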

Compound 4, dose for half-maximal effect: 300 mg/kg
The estimate for compound 4 lay 2.0-fold (0.30 log units) below the measured number; low and high end bracket the measured number.
By their numbers in this assay, from the lowest: compounds 2 and 3 (each within the scatter of the next); then compounds 1 and 4 (each within the scatter of the next).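

In this assay, going from 4-nitrophenyl to 4-methoxyphenyl gives no change at the digits printed from compound 1 to compound 4 (within the scatter), so at this aromatic carbon, para to a large group, the read-out does not separate nitro from methoxy. The earlier compounds shown here showed methoxy only at a different site, where it replaced methyl and gave a 3.0-fold lower number from compound 1 to compound 2 (0.48 log units; beyond the scatter); the entry of methoxy therefore does not produce the same outcome at the two sites. Nothing measured on hand bears on why the number holds at this position.

The compounds shown leave open whether an amine, a carboxylic acid or a longer chain such as ethoxy at this aromatic carbon would move the number beyond the scatter, or whether the lack of change is confined to the nitro and methoxy pair. Also open, as far as these compounds go, is whether the step seen for compound 2 would persist with 4-methoxyphenyl in place of 4-nitrophenyl, as a compound carrying methoxy at both sites would be needed to read that.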